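The source may hold more compounds than are shown below. What is called first, only, known or untested is meant among the compounds shown, and "the series" means these compounds.

In a functional assay on SEM cells (Homo sapiens) for cytotoxicity, with a stated time of 72 h (on this read-out higher numbers stand for an effect only at larger amounts of compound and lower numbers for an effect already at smaller amounts), compound 1 `C=C[C@@](C)(/C=C/c1ccc(O)c(/C=C/C(=O)OCC)c1)CCC=C(C)C` gives > 36600 nM, which is a limit of the assay. Compound 2 `C=C[C@@](C)(/C=C/c1ccc(O)c(/C=C/c2ccc(F)cc2)c1)CCC=C(C)C` gives > 36600 nM, again a limit. Compound 3 `CCOC(=O)/C=C/c1cc(/C=C/[C@](C)(/C=C/c2ccc(OC)cc2)CCC=C(C)C)ccc1O` gives > 36600 nM, also a limit. Compound 3 therefore stands at the limit of > 36600 nM in this assay, at which 3 of the 3 values shown sit. Compound 4 `COc1ccc(/C=C/[C@@](C)(/C=C/c2ccc(O)c(/C=C/C(=O)c3ccccc3)c2)CCC=C(C)C)cc1` carries phenyl in place of ethoxy on a carbonyl carbon, turning ethoxycarbonyl into benzoyl: phenyl in place of ethoxy on a carbonyl carbon. For the measured compounds named here, two measured steps bear on this, a step that the two limits leave unreadable from compound 1 to compound 2 and a step that the two limits leave unreadable from compound 1 to compound 3, and neither has a readable size. They offer no size or direction to carry over, so compound 4 is expected to stay near that limit. The expected change is an at least 1.2-fold lower number from compound 3 to compound 4 (0.08 log units; that floor lies within the scatter), with no firm direction. Compound 4 is estimated at 30000 nM, with an expected range from 10000 nM to 60000 nM.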

Compound 4, half-maximal effective concentration: 36600 nM
Beside the measured number, compound 4's estimate is 1.2-fold (0.09 log units) below it, within the range that was stated.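

In this assay, for the compounds shown here, compound 4 gives 36600 nM as a measured number, the first such value. Phenyl in place of ethoxy on a carbonyl carbon, turning ethoxycarbonyl into benzoyl, gives a number no higher from compound 3 to compound 4 (the limit leaves the size open) and so shows only that this change does not raise the number, while the earlier steps cannot be read. The series as a whole still sits at one edge: the limit of > 36600 nM in this assay, at which 3 of the 4 values shown sit.

Going by these compounds, whether an amine or a carboxylic acid on this carbonyl carbon would bring the number lower remains open. So does the true size of this step.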